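Amide analogues of a threonine scaffold in a liver-cell cytotoxicity assay

This account rests on a few compounds, and the source may have more. Where it says the series, first, only, none or still open, it means among the compounds named here.

Measured compounds:
compound 1 `CCCCCCCCCCCCCCCCCCNC(=O)[C@@H](N)[C@@H](C)O`: 44500 nM
compound 2 `CCCCCCCCNC(=O)[C@@H](NC(=O)c1ccco1)[C@@H](C)O`: 192000 nM
compound 3 `CCCCCCCCCCCCNC(=O)[C@@H](NC(=O)c1ccco1)[C@@H](C)O`: 147000 nM

In a functional assay on HepG2 cells (Homo sapiens) for cytotoxicity, read by MTT assay, with a stated time of 48 h (on this read-out lower numbers stand for stronger inhibition and higher numbers for weaker inhibition), compound 3 gives 147000 nM, which is the second highest of the three numbers. Its nearest neighbour is compound 2 with 192000 nM, and the step of a 1.3-fold lower number from compound 2 to compound 3 (0.12 log units; within the scatter) separates the two. Going by the values given here, compound 1, the free amine with the longest chain, gives 44500 nM, a number beyond the scatter from compound 3 in the direction of stronger inhibition; no single-point step between compound 1 and compound 3 is defined, so only the two values themselves can be compared.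

Compound 4 `CCCCCCCCCCCCNC(=O)[C@@H](NC(=O)c1nccc2ccccc12)[C@@H](C)O` differs from compound 3 by isoquinolin-1-yl in place of furan-2-yl on a carbonyl carbon. Among the compounds with values here, none of the measured steps touches the acyl group on the amide-type nitrogen: the only step on record, a 1.3-fold lower number from compound 2 to compound 3 (0.12 log units; within the scatter), concerns the saturated chain and lay within the scatter. The data therefore give no direct guide for exchanging a five-membered aromatic ring for a fused bicyclic one on the carbonyl carbon.

Compound 4 is expected to show a step of about a 1.5-fold lower number from compound 3 to compound 4 (0.17 log units; within the scatter) in this assay, a change that is estimated not to exceed the scatter with confidence. Compound 4 is estimated at 100000 nM, with a range of 40000 nM to 250000 nM.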

Compound 4, half-maximal inhibitory concentration: 65700 nM
Compound 4: middle estimate off by 1.5-fold (0.18 log units), on the high side; the range from low to high includes it.
By their numbers in this assay, from the lowest: compounds 1 and 4 (each within the scatter of the next); then compounds 3 and 2 (each within the scatter of the next).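

In this assay, going by these compounds alone, the step of a 2.2-fold lower number from compound 3 to compound 4 (0.35 log units; beyond the scatter) is the first measured change at the acyl group on the amide-type nitrogen, and it lies beyond the scatter, though modestly. Within the data shown here, the earlier step on the saturated chain, a 1.3-fold lower number from compound 2 to compound 3 (0.12 log units; within the scatter), stayed within the scatter, so the group on the carbonyl carbon is the first place where a single exchange is seen to shift the number, with the chain and the rest of the shared core held constant. Nothing measured here accounts for that shift, and the exchange changes the ring system, the hetero atom and the number of heavy atoms all at once.

The compounds shown leave open which of those differences matters: a phenyl, a pyridin-2-yl or a naphthalen-1-yl group on the same carbonyl carbon would begin to separate the second ring from the ring nitrogen. They also leave open whether isoquinolin-1-yl in place of furan-2-yl gives a similar step on the shorter chain of compound 2 , or whether the step depends on the chain carried by compound 3 .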